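Salicylaldimine series: chloro for nitro on compound 1

The source may hold more compounds than are shown below. What is called first, only, known or untested is meant among the compounds shown, and "the series" means these compounds.

Three salicylaldimines sharing a benzyloxyphenyl imine core have been measured in an assay on isolated protein for inhibition of Amine oxidase [flavin-containing] B (Homo sapiens), read by fluorescence and Amplex Red, with stated times of 15 min and 20 min; a higher number here means a weaker inhibitor, a lower number a stronger inhibitor. Compound 1 `O=[N+]([O-])c1ccc(O)c(/C=N/c2ccc(OCc3ccccc3)cc2)c1` gives 60900 nM, the highest of the three numbers and the weakest inhibitor of the set. Compound 2 `Oc1ccc(/C=N/c2ccc(OCc3ccccc3)cc2)c(O)c1O` gives 1730 nM, and compound 3 `COc1ccc(/C=N/c2ccc(OCc3ccccc3)cc2)c(O)c1` gives 23600 nM; both lie beyond the scatter from compound 1, compound 2 far more so than compound 3.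

Compound 4 `Oc1ccc(Cl)cc1/C=N/c1ccc(OCc2ccccc2)cc1` is not yet measured. It differs from compound 1 in one place: chloro in place of nitro on an aromatic carbon. Within the data shown here, no measured pair in the set carries this exact change, so the size of the step is not known from neighbours. The remaining compounds show that substituents on the phenol ring move the number by substantial amounts, so a step beyond the scatter in this assay is plausible, and the expectation is a moderate move toward a lower number. The estimated step from compound 1 to compound 4 in this assay is a 4.1-fold lower number from compound 1 to compound 4 (0.61 log units; beyond the scatter). Compound 4 is expected to give 15000 nM in this assay, with a range from 4000 nM to 55000 nM.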

Compound 4, half-maximal inhibitory concentration: 24800 nM
Compound 4: middle estimate off by 1.7-fold (0.22 log units), on the low side, and the stated range covers the measured number.
By their numbers in this assay, from the lowest: compound 2; then compounds 3 and 4 (each within the scatter of the next); then compound 1.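

In this assay, the place para to a hydroxy group now has its first step in one place: chloro in place of nitro gives a 2.5-fold lower number from compound 1 to compound 4 (0.39 log units; beyond the scatter) and so moves the number modestly downward. This position therefore responds to the change, and the nitro group with its 3 heavy atoms and 2 hydrogen-bond acceptors can give way to a single chlorine without a rise in the number. Nothing at hand accounts for the size of this step.

Going by these compounds, whether the lower number belongs to chloro in particular stays open, since a single pair cannot rank other groups at this place, such as an amine or a carboxylic acid. Also open, on these data alone, is whether the same change gives a similar step on the core of compound 2.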